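A few compounds are considered here, and "the series" means these few. Any claim that something is new, unique, unknown or untested is made for them only; others in the source may bear on it.

Compound 3 `COc1ccc(C2CC(c3ccccc3)=NN2C2=NC(=O)/C(=C3\C(=O)Nc4ccc(Br)cc43)S2)cc1` gives the lowest of the three numbers measured in a functional assay on cells (Cancer cell lines, Homo sapiens) for cytotoxicity, read by sulforhodamine B assay, with a stated time of 48 h (on this read-out higher numbers stand for weaker inhibition of growth and lower numbers for stronger inhibition of growth), namely 200 nM. Compound 1 `O=C1N=C(N2N=C(c3ccccc3)CC2c2ccccc2O)S/C1=C1/C(=O)Nc2ccc(Br)cc21` gives 240 nM in this assay, and the change from it, a 1.2-fold lower number from compound 1 to compound 3 (0.08 log units; within the scatter), lies within the scatter. Compound 2 `COc1ccc(C2CC(c3ccccc3)=NN2C2=NC(=O)/C(=C3\C(=O)Nc4ccccc43)S2)cc1` gives 2380 nM in this assay, and the step of a 12-fold lower number from compound 2 to compound 3 (1.08 log units; beyond the scatter) is the one large move in the set. Compound 4 `COc1ccc(C2CC(c3ccc4ccccc4c3)=NN2C2=NC(=O)/C(=C3\C(=O)Nc4ccc(Br)cc43)S2)cc1` is not yet measured; it differs from compound 3 in one place: naphthalen-2-yl in place of phenyl on a carbon with a double bond to nitrogen. Neither measured step touches this site: one concerns the group on the saturated ring carbon, the other the bromo on an aromatic carbon, so the data offer no direct guide to the effect of the larger aromatic group here. Among the measured compounds shown here, with no step bearing on the change, the expected move in this assay is none beyond the scatter, so compound 4 is expected to give about 200 nM, somewhere between 70 nM and 600 nM, which corresponds to an estimated step of no change at the digits printed from compound 3 to compound 4 (within the scatter).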

Compound 4, concentration for 50% growth inhibition: 54 nM
For compound 4 the middle estimate is 3.7-fold (0.57 log units) above the measured one; the measured number lies below the stated range.
By their numbers in this assay, from the lowest: compound 4; then compounds 3 and 1 (each within the scatter of the next); then compound 2.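

Among the compounds shown here, at the carbon with a double bond to nitrogen, which no earlier step touched, the result shows that the group carried there matters: naphthalen-2-yl in place of phenyl gives a 3.7-fold lower number from compound 3 to compound 4 (0.57 log units; beyond the scatter) in this assay. This position therefore accepts a group with two six-membered aromatic rings of carbon only, and growth inhibition grows stronger rather than being lost. Nothing available explains why this change lowers the number.

Only phenyl and naphthalen-2-yl stand at this position, so one step cannot tell whether the gain follows from the size of the group or from its particular shape, and a pyridine ring, a morpholine or a plain methyl there remains untested in the compounds shown. Going by these compounds, it also remains open whether the same change would lower the number on the 2-hydroxyphenyl compound 1 or on compound 2, which lacks the bromo.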